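A few compounds are considered here, and "the series" means these few. Any claim that something is new, unique, unknown or untested is made for them only; others in the source may bear on it.

Working notes, growth inhibition of DU-145 cells.

Compound 1 `COc1ccc(/C=C(\C(=O)c2ccc(Cl)cc2)S(=O)(=O)Cc2ccccc2Cl)cc1` gives 50000 nM in a functional assay on DU-145 cells (Homo sapiens) for inhibition, read by trypan blue exclusion, with a stated time of 96 h; a higher number here means a weaker inhibitor of growth, a lower number a stronger inhibitor of growth.
Compound 2 `COc1ccc(/C=C(\C(=O)c2ccc(Cl)cc2)S(=O)(=O)c2ccc(Br)cc2)cc1` gives 10000 nM in this assay.
Compound 3 `COc1ccc(/C=C(\C(=O)c2ccc(Br)cc2)S(=O)(=O)c2ccc(Br)cc2)cc1` gives 25000 nM in this assay.

Compound 2 has the lowest number of the three in this assay. The step of a 5.0-fold lower number from compound 1 to compound 2 (0.70 log units; beyond the scatter) separates it from compound 1, and the step of a 2.5-fold higher number from compound 2 to compound 3 (0.40 log units; beyond the scatter) separates it from compound 3, so both neighbours stand beyond the scatter from it.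

The next compound, compound 4 `CN(C)c1ccc(/C=C(\C(=O)c2ccc(Cl)cc2)S(=O)(=O)c2ccc(Br)cc2)cc1`, is reached from compound 2 by a single change: dimethylamino in place of methoxy on an aromatic carbon. Neither measured step bears directly on this change. For the measured compounds named here, the step of a 5.0-fold lower number from compound 1 to compound 2 (0.70 log units; beyond the scatter) concerns the group on the sulfonyl sulfur, and the step of a 2.5-fold higher number from compound 2 to compound 3 (0.40 log units; beyond the scatter) concerns the halogen on the aryl ketone; no measured pair differs at the methoxy group. The series therefore gives no measured guide to the size or direction of the step in this assay from compound 2 to compound 4, and the expectation is a step not beyond the scatter, with a wide range to either side.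

Compound 4 is thus estimated at 8000 nM in this assay, with a range from 2500 nM to 30000 nM, which means an expected step of a 1.3-fold lower number from compound 2 to compound 4 (0.10 log units; within the scatter).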

Compound 4, concentration for 50% growth inhibition: > 100000 nM
Compound 4 was reported as a limit; the forecaster's own chance of this, stated with the estimate: 10%; at least 12-fold (1.09 log units) between middle value and limit.
By their numbers in this assay, from the lowest: compound 2; then compounds 3 and 1 (each within the scatter of the next). At a limit, above all of these: compound 4.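

For the compounds shown here, the earlier compounds varied only the group on the sulfonyl sulfur and the halogen on the aryl ketone, whereas this result is the first reading on the aromatic carbon para to a large group, and this position proves far from indifferent: going from 4-methoxyphenyl to 4-(dimethylamino)phenyl gives an at least 10-fold higher number from compound 2 to compound 4 (1.00 log units; beyond the scatter). Compound 4 gives > 100000 nM in this assay, which is a limit of the assay and not a number, so the step has a floor but no measured size. Compound 4 stands alone at the top of the reported range: the limit of > 100000 nM in this assay, at which 1 of the 4 values shown sits.

Whether a hydroxyl, a primary amine or an ethoxy group at this position would read like methoxy or like dimethylamino remains open, so the compounds shown do not tell which feature of the change matters. Also open, on these data alone, is whether dimethylamino in place of methoxy would have the same outcome with 2-chlorobenzyl on the sulfonyl sulfur or with bromo on the aryl ketone, as the change is seen in one setting only.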